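The source may hold more compounds than are shown below. What is called first, only, known or untested is meant among the compounds shown, and "the series" means these compounds.

Notes on the series in a functional assay on DU-145 cells (Homo sapiens) for antiproliferative activity, read by MTT assay, with a stated time of 48 h; on this read-out higher numbers stand for weaker inhibition and lower numbers for stronger inhibition. Compound 3 `COc1ccccc1-n1cc(COC(=O)/C(C)=C/CC/C(C)=C/CC/C(C)=C/CC[C@@H]2[C@@]3(C)CCC(=O)C(C)(C)[C@H]3CC[C@@]2(C)O)nn1` carries a 2-methoxyphenyl on the aromatic nitrogen; in this assay compound 3 gives > 150000 nM, a limit of the assay rather than a number. Compound 1 `C/C(=C\CC/C(C)=C/CC[C@@H]1[C@@]2(C)CCC(=O)C(C)(C)[C@H]2CC[C@@]1(C)O)CC/C=C(\C)C(=O)OCc1cn(-c2ccc([N+](=O)[O-])cc2)nn1` gives in this assay > 150000 nM, likewise a limit. Compound 2 `C/C(=C\CC/C(C)=C/CC[C@@H]1[C@@]2(C)CCC(=O)C(C)(C)[C@H]2CC[C@@]1(C)O)CC/C=C(\C)C(=O)OCc1cn(-c2ccc(F)c(Cl)c2)nn1` gives in this assay > 150000 nM, also a limit. Among the measured compounds shown here, the whole set thus shares (the limit of > 150000 nM in this assay, at which 3 of the 3 values shown sit), so the steps a step that the two limits leave unreadable from compound 1 to compound 2, a step that the two limits leave unreadable from compound 1 to compound 3 and a step that the two limits leave unreadable from compound 2 to compound 3 cannot be read, and no measured step resolves the effect of the aryl group on the aromatic nitrogen. Compound 4 `COc1ccc(-n2cc(COC(=O)/C(C)=C/CC/C(C)=C/CC/C(C)=C/CC[C@@H]3[C@@]4(C)CCC(=O)C(C)(C)[C@H]4CC[C@@]3(C)O)nn2)cc1` differs from compound 3 by 4-methoxyphenyl in place of 2-methoxyphenyl on an aromatic nitrogen. No readable step bears on this change. Compound 4 is therefore expected to remain at the limit too, estimated at 200000 nM, with a range of 80000 nM to 500000 nM. The expected step is a step that the limit leaves unreadable from compound 3 to compound 4.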

Compound 4, half-maximal inhibitory concentration: 135000 nM
Beside the measured number, compound 4's estimate is 1.5-fold (0.17 log units) above it, within the range that was stated.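

In this assay compound 4, with 4-methoxyphenyl on the aromatic nitrogen, is the only compound shown that gives a number rather than a limit, so steps at this position can now be bounded: an at least 1.1-fold lower number from compound 3 to compound 4 (0.04 log units; that floor lies within the scatter), an at least 1.1-fold lower number from compound 2 to compound 4 (0.04 log units; that floor lies within the scatter) and an at least 1.1-fold lower number from compound 1 to compound 4 (0.04 log units; that floor lies within the scatter). Each of these floors lies within the scatter, so none establishes a real difference between the aryl groups. The other three compounds share one limit: the limit of > 150000 nM in this assay, at which 3 of the 4 values shown sit.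

As far as these compounds go, how far compounds 1, 2 and 3 actually lie from compound 4 stays open. Also open, from the compounds shown here alone, is whether an amine or a carboxylic acid in place of methoxy would give a step beyond the scatter.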